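Shortening and Branching the Acid Chain on the Shared Core

A few compounds are considered here, and "the series" means these few. Any claim that something is new, unique, unknown or untested is made for them only; others in the source may bear on it.

Measured so far:
compound 1 `CN(c1cnccc1SCCCCC(=O)O)c1ccc(C#N)c2ccccc12`: 3580 nM
compound 2 `N#Cc1ccc(Oc2cnccc2SCCCCCCC(=O)O)c2ccccc12`: 3780 nM
compound 3 `N#Cc1ccc(Nc2cnccc2SCCCCC(=O)O)c2ccccc12`: 2280 nM

All three were tested in an assay on HEK293 cells for inhibition of solute carrier family 22 member 12 (Homo sapiens), read by scintillation counting, with stated times of 30 min and 15 min; on this read-out lower numbers stand for stronger inhibition and higher numbers for weaker inhibition. The number for compound 1 is the second highest of the three, but its gaps to compound 2 and to compound 3 both lie within the scatter, so the three compounds cannot be told apart on this read-out. Within the data shown here, the only measured change at a single place, a 1.6-fold lower number from compound 1 to compound 3 (0.20 log units; within the scatter), puts hydrogen in place of methyl on the nitrogen that links the two aromatic parts, and this step too stays within the scatter.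

The next compound, compound 4 `CN(c1cnccc1SC(C)(C)C(=O)O)c1ccc(C#N)c2ccccc12`, differs from compound 1 at the chain that carries the acid: 1-carboxy-1-methylethyl in place of 4-carboxybutyl on a sulfur. Among the measured compounds shown here, no measured step touches this chain. For the measured compounds named here, compound 2 carries a longer acid chain than compound 1, but it also differs at the linking atom, so its value shows only that the two numbers are close. With nothing in the data bearing on this change, the expectation is a step of no more than the scatter in this assay, stated as a 1.4-fold higher number from compound 1 to compound 4 (0.15 log units; within the scatter), with a wide margin. Compound 4 is therefore estimated at 5000 nM, expected between 1200 nM and 20000 nM.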

Compound 4, half-maximal inhibitory concentration: 5360 nM
Estimate against measurement, compound 4: 1.1-fold (0.03 log units) below, within the range that was stated.
By their numbers in this assay, from the lowest: compounds 3, 1, 2 and 4 (each within the scatter of the next, the first and the last beyond it).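

Among these compounds, compound 4 gives the first reading on a change to the chain that carries the acid: in this assay, 1-carboxy-1-methylethyl in place of 4-carboxybutyl on a sulfur gives a 1.5-fold higher number from compound 1 to compound 4 (0.18 log units; within the scatter) and so stays within the scatter. This position therefore accepts a move from an unbranched chain of 7 heavy atoms to a branched one of 6 heavy atoms, with the carboxylic acid kept, without a shift that this read-out can separate from repeat-to-repeat variation. No measurement here accounts for this result, so it stands as an observation without an explanation.

Because shortening and branching arrive together in this single step, the compounds shown cannot say what each does alone; a carboxymethyl group on the sulfur, which is short but has no branch, would pull the two apart, and a 1-carboxycyclopropyl group would tie the branch into a ring. Also open, from the compounds shown here alone, is how much depends on the acid itself, which an amide or a primary alcohol at the end of the chain would test.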